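The compounds below may be only part of what the source reports. "The series", "measured", "known", "first", "only" and "open" are said of these compounds alone.

Measured so far in an assay on isolated protein for inhibition of DNA topoisomerase 1 (Homo sapiens), tested at 20 uM; a lower number here means a weaker effect, a higher number a stronger effect of the compound at the concentration tested:
- compound 1 `O=C(/C=C/c1ccc(N2CCCC2)cc1)c1ccc(O)cc1`: 60%
- compound 2 `O=C(/C=C/c1ccc(N2CCCC2)cc1)c1ccc(F)cc1`: 73.1%

Compound 2 gives the highest of the two numbers in this assay; its nearest neighbour is compound 1, and the step of a number 13.1 percentage points higher from compound 1 to compound 2 (beyond the scatter) lies beyond the scatter, a modest rise.

Compound 3 `O=C(/C=C/c1ccc(N2CCCC2)cc1)c1ccc([N+](=O)[O-])cc1` is the next member to be tested. Relative to compound 2 the change is nitro in place of fluoro on an aromatic carbon.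

Among the compounds with values here, only one measured step exists, a number 13.1 percentage points higher from compound 1 to compound 2 (beyond the scatter), and it concerns hydroxy against fluoro; no measured step involves a nitro group, so nothing bears directly on this change. With the two measured values sitting fairly close together, the expectation for compound 3 is a step of a number 3.1 percentage points lower from compound 2 to compound 3 (within the scatter), that is, no clear movement beyond the scatter in either direction. Compound 3 is therefore estimated at 70%, within a range from 50% to 88%.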

Compound 3, a percentage reported as inhibition, at one concentration (the size of the read-out at that concentration, not a potency): 77.6%
Estimate against measurement, compound 3: 7.6 percentage points below; the range from low to high includes it.
By their numbers in this assay, from the lowest: compound 1; then compounds 2 and 3 (each within the scatter of the next).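

With a number 4.5 percentage points higher from compound 2 to compound 3 (within the scatter) the position on the aromatic carbon para to a large group takes nitro and fluoro alike in this assay, even though nitro brings more heavy atoms and hydrogen-bond acceptors than fluoro. With a number 17.6 percentage points higher from compound 1 to compound 3 (beyond the scatter) a second replacement of hydroxy now clears the scatter, so compound 2 and compound 3 both stand apart from compound 1 in this short set. No evidence on hand accounts for the separation of hydroxy from the other two groups.

From the compounds shown here alone, whether an amine, a carboxylic acid or a methoxy group at this position would stay level with fluoro and nitro or sit nearer hydroxy remains open. Also open, going by these compounds, is whether the same order of groups would hold with a change elsewhere on the shared core.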